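The compounds below may be only part of what the source reports. "The series", "measured", "known", "first", "only" and "open" are said of these compounds alone.

Working notes on the series. In an assay on RPMI-8866 cells for inhibition of integrin alpha-4/beta-1 (Homo sapiens) (a lower number here means a stronger inhibitor, a higher number a weaker inhibitor), compound 1 `O=C(O)C[C@@H](NC(=O)[C@@H]1CCN1S(=O)(=O)c1cc(Cl)cc(Cl)c1)c1ccc(OC2CCCC2)cc1` gives 0.5 nM and stands lowest of the two numbers recorded so far. Going by the values given here, the nearest measured neighbour is compound 2 `O=C(O)C[C@@H](NC(=O)[C@@H]1CCN1S(=O)(=O)c1cc(Cl)cc(Cl)c1)c1ccc(Cl)c(F)c1`, which in this assay gives 11 nM, a gap that lies beyond the usual scatter; no single-point step between the two is recorded, so only the two values themselves are noted. Compound 3 `O=C(O)C[C@@H](NC(=O)[C@@H]1CCN1S(=O)(=O)c1cc(Cl)cc(Cl)c1)c1ccc(Oc2ccccc2)cc1` is not yet measured. It differs from compound 1 in one place: phenyl in place of cyclopentyl on an oxygen on an aromatic ring. Among the compounds with values here, with no measured step for this kind of change, the expectation rests on compound 1 alone, whose value 0.5 nM anchors the estimate. The change from compound 1 to compound 3 is expected to be small, a 2.4-fold higher number from compound 1 to compound 3 (0.38 log units; beyond the scatter), toward a somewhat higher number, and may well fall within the scatter. For compound 3 the estimate in this assay is 1.2 nM, with a range from 0.3 nM to 5 nM.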

Compound 3, half-maximal inhibitory concentration: 3.1 nM
The estimate for compound 3 lay 2.6-fold (0.41 log units) below the measured number; the measured number falls inside the stated range.
By their numbers in this assay, from the lowest: compound 1; then compound 3; then compound 2.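

In this assay, going by these compounds alone, the step at this position, on an oxygen on an aromatic ring, is a 6.2-fold higher number from compound 1 to compound 3 (0.79 log units; beyond the scatter), the first measured change of the group on that oxygen. The two groups are therefore not interchangeable here, although the step is modest and compound 3 at 3.1 nM retains a low number with a six-membered aromatic ring in place of the five-membered non-aromatic one. Nothing recorded for the series bears on the cause of this step.

The compounds shown leave open whether ring size or aromatic character accounts for the step, as the two change together from cyclopentyl to phenyl. Cyclohexyl on the same oxygen would address ring size alone, while a pyridyl ring or an open butyl chain would show how far the preference for a carbon ring extends.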